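The source may report more compounds than this note shows. Statements on the series, on what has been measured and on what is new or still open speak of the compounds shown alone.

Compound 1, `Cc1ccc(S(=O)(=O)N2CC=C(Cl)CC2)cc1`, gives in a functional assay on WiDr cells (Homo sapiens) for antiproliferative activity, read by sulforhodamine B assay, with a stated time of 48 h (a higher number here means a weaker inhibitor of growth, a lower number a stronger inhibitor of growth), a limit rather than a number: > 100000 nM.
Compound 2, `Cc1ccc(S(=O)(=O)N2CCC(Cl)=CC2CC(C)C)cc1`, gives in this assay 21000 nM.
Compound 3, `Cc1ccc(S(=O)(=O)N2CCC(Cl)=CC2C2CCCCC2)cc1`, gives in this assay 24000 nM.

Compound 2 holds the lowest of the two numbers, but its neighbour compound 3 sits within the scatter: a 1.1-fold higher number from compound 2 to compound 3 (0.06 log units; within the scatter). Compound 1 stands at a limit, (the limit of > 100000 nM in this assay, at which 1 of the 3 values shown sits), so its steps to the others can only be given as bounds: an at least 4.7-fold lower number from compound 1 to compound 2 (0.67 log units; beyond the scatter) and an at least 4.1-fold lower number from compound 1 to compound 3 (0.61 log units; beyond the scatter). Both bounds concern a group entering on a saturated ring carbon of the shared core.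

Compound 4, `Cc1ccc(S(=O)(=O)N2CCC(Br)=CC2CC(C)C)cc1`, differs from compound 2 in another way: bromo in place of chloro on a double-bonded ring carbon. For the measured compounds named here, none of the measured steps touches the halogen on the double-bonded ring carbon; the two steps that are beyond the scatter concern the saturated ring carbon, and the one step at the halogen-bearing core, that from compound 2 to compound 3, is within the scatter. Going by the values given here, no measured step therefore bears directly on this change. The expectation is a step of no size beyond the scatter: a 1.2-fold lower number from compound 2 to compound 4 (0.07 log units; within the scatter). Compound 4 is accordingly expected to give 18000 nM in this assay, between 8000 nM and 45000 nM.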

Compound 4, concentration for 50% growth inhibition: 16000 nM
Beside the measured number, compound 4's estimate is 1.1-fold (0.05 log units) above it; low and high end bracket the measured number.
By their numbers in this assay, from the lowest: compounds 4, 2 and 3 (each within the scatter of the next). At a limit, above all of these: compound 1.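

For the compounds shown here, the halogen on the double-bonded ring carbon, which no earlier step touched, can now be read: with the isobutyl group kept in place, bromo in place of chloro gives a 1.3-fold lower number from compound 2 to compound 4 (0.12 log units; within the scatter) in this assay. Going by these compounds alone, at this position and with this group on the saturated ring carbon, one halogen thus stands for the other without a change beyond the scatter, whereas the only steps beyond the scatter so far remain those from compound 1 at the saturated ring carbon. Nothing measured here accounts for the size of this step.

Going by these compounds, what an amine or a methyl group on the double-bonded ring carbon would give remains open. So does whether bromo in place of chloro gives a step of similar size with the cyclohexyl group of compound 3.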